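Three Cytotoxicity Limits and a Fourth Sulfonamide

The source may report more compounds than this note shows. Statements on the series, on what has been measured and on what is new or still open speak of the compounds shown alone.

Compound 1 `CC1CCN(C2CCN(S(=O)(=O)c3cn(C)cn3)CC2)CC1`: > 10000 nM
Compound 2 `CC1CCN(C2CCN(S(=O)(=O)c3cccc(-c4ccccc4F)c3)CC2)CC1`: > 5000 nM
Compound 3 `CC1CCN(C2CCN(S(=O)(=O)c3cccnc3Cl)CC2)CC1`: > 10000 nM

In an ADME assay on HCT-116 cells (Homo sapiens) for cytotoxicity, read by CellTiter-Glo, with a stated time of 72 h (on this read-out lower numbers stand for stronger inhibition and higher numbers for weaker inhibition), compound 1 returns > 10000 nM, which is a limit of the assay rather than a number. In this assay compound 2 returns > 5000 nM, also a limit. Compound 3 likewise returns > 10000 nM in this assay, a limit once more. Within the data shown here, the one single-point step among the measured compounds, a step that the two limits leave unreadable from compound 1 to compound 3, therefore cannot be read, since both ends sit at limits. Among the measured compounds shown here, compound 3 thus stands at the limit of > 10000 nM in this assay, at which 2 of the 3 values shown sit, with no measured compound of this series showing a number at all; the only other kind of result is the limit of > 5000 nM in this assay, at which 1 of the 3 values shown sits.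

Compound 4 `Cc1cccc(S(=O)(=O)N2CCC(N3CCC(C)CC3)CC2)c1` differs from compound 3 in one place: 3-methylphenyl in place of 2-chloropyridin-3-yl on a sulfonyl sulfur. For the measured compounds named here, no measured step bears on this change, and the steps that exist are themselves unreadable, so no direction and no size beyond the scatter can be expected for the step in this assay. Compound 4 is therefore expected to sit where the measured compounds sit, with an estimated step that the limit leaves unreadable from compound 3 to compound 4. For compound 4 the estimate is 20000 nM, within a range from 5000 nM to 100000 nM, most probably reported as a limit.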

Compound 4, half-maximal inhibitory concentration: > 5000 nM
Compound 4 was reported as a limit; the forecaster's own chance of this, stated with the estimate: 85%; the middle value lies beyond the limit too.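

In this assay compound 4 returns > 5000 nM, which is a limit of the assay. Its steps from compound 1, compound 2 and compound 3 therefore cannot be read, and all four compounds now rest on limits. The compounds shown leave open whether changing the group on the sulfonyl sulfur alters this read-out at all, and by how much.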